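The source may hold more compounds than are shown below. What is called first, only, known or untested is meant among the compounds shown, and "the series" means these compounds.

Measured so far in an ADME assay (liver) for metabolic stability, with Liver microsome (Rattus norvegicus) as the target, read by LC-MS, using microsomes and NADPH, with stated times of 5 min and 60 min, tested at 4 uM; on this read-out higher numbers stand for a more stable compound and lower numbers for a less stable compound:

compound 1 `Cc1c(OCCCCOc2ccc(C(=O)O)cc2Cl)ccc(C(=O)CC2CCCC2)c1O`: 21%
compound 2 `Cc1c(OCCCCOc2ccc(C(=O)CC(C)(C)C)c(O)c2C)cccc1C(=O)O`: 51%
compound 3 `Cc1cc(OCCCCOc2ccc(C(=O)CC3CCCC3)c(O)c2C)ccc1C(=O)O`: 55%

Compound 3 holds the highest of the three numbers. Its nearest neighbour is compound 2, whose value lies within the scatter of that of compound 3, so no order can be read between those two. Compound 1 lies far below, and the step of a number 34 percentage points higher from compound 1 to compound 3 (beyond the scatter) is beyond the scatter.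

Compound 4 `Cc1c(OCCCCOc2ccc(C(=O)O)cc2F)ccc(C(=O)CC2CCCC2)c1O` has not yet been measured in this assay. It differs from compound 3 in one place: 4-carboxy-2-fluorophenyl in place of 4-carboxy-3-methylphenyl on an oxygen on a saturated carbon. Among the measured compounds shown here, only one measured step bears on this change, the one in which a 4-carboxy-3-methylphenyl replaced a 4-carboxy-2-chlorophenyl on the same oxygen, and that step was large: a number 34 percentage points higher from compound 1 to compound 3 (beyond the scatter). For the measured compounds named here, compound 4 carries a 4-carboxy-2-fluorophenyl, closer in kind to the 4-carboxy-2-chlorophenyl of compound 1 than to the group in compound 3, yet no measured pair shows how a fluorine and a chlorine in that place compare. A downward step beyond the scatter is therefore expected for compound 4, estimated at a number 22 percentage points lower from compound 3 to compound 4 (beyond the scatter), with a wide margin. Compound 4 is expected to give about 33% in this assay, in the range 15% to 55%.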

Compound 4, percent of the compound remaining: 66%
Compound 4: the middle estimate sits 33 percentage points below what was measured; the whole stated range lies below it.
By their numbers in this assay, from the lowest: compound 1; then compounds 2 and 3 (each within the scatter of the next); then compound 4.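

In this assay, among the compounds shown here, the exchange of chloro for fluoro on an aromatic carbon, with the rest of the molecule unchanged, gives a number 45 percentage points higher from compound 1 to compound 4 (beyond the scatter) and so separates the two halogens for the first time; the earlier compounds held no such pair. The 4-carboxy-2-fluorophenyl on an oxygen on a saturated carbon also outdoes the 4-carboxy-3-methylphenyl, with a number 11 percentage points higher from compound 3 to compound 4 (beyond the scatter) beyond the scatter, so among these compounds the low number of compound 1 goes with the 4-carboxy-2-chlorophenyl specifically and not with any halogen on that ring. Nothing available explains why the two halogens differ so widely.

From the compounds shown here alone, it remains open how a hydrogen, a bromine, a methoxy or a nitrile would compare with fluoro and chloro in that place, and whether an amide or a tetrazole could stand in for the carboxylic acid. Going by these compounds, the fluoro and chloro pair also rests on a single core with the cyclopentyl ketone, so it is unknown whether the same gap would appear with the side chain of compound 2.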